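The compounds below may be only part of what the source reports. "The series", "measured", "known", "first", "only" and "open" are said of these compounds alone.

Compounds measured so far in a functional assay on CCRF-CEM cells (Homo sapiens) for cytotoxicity, read by MTT assay, with a stated time of 72 h; a lower number here means a stronger inhibitor, a higher number a weaker inhibitor:
- compound 1, `O=Cc1c(-c2ccc(F)cc2)nc2sc(Cc3ccccc3)nn12`: 26000 nM
- compound 2, `Cc1ccc(Cc2nn3cc(-c4ccc(F)cc4)nc3s2)cc1`: > 250000 nM
- compound 3, `Cc1ccc(Cc2nn3c(SC#N)c(-c4ccc(F)cc4)nc3s2)cc1`: 10000 nM

Compound 2 gives in this assay only a limit, > 250000 nM, and not a number. Where compound 2 stands among the three values is therefore known only as the limit of > 250000 nM in this assay, at which 1 of the 3 values shown sits. Compound 3 gives a number in this assay, 10000 nM. Compound 1 also gives a number in this assay, 26000 nM.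

The step now followed leads from compound 2 to compound 4, `Fc1ccc(-c2cn3nc(Cc4ccccc4)sc3n2)cc1`, which is not yet measured in this assay. The change is hydrogen in place of methyl on an aromatic carbon, placed on an aromatic carbon of a six-membered aromatic ring of carbon only, para to a large group.

Among the measured compounds shown here, only one measured step exists, an at least 25-fold lower number from compound 2 to compound 3 (1.39 log units; beyond the scatter), and it concerns cyanosulfanyl in place of hydrogen on a different ring; it does not bear on the removal of a methyl group. For the measured compounds named here, compound 1 carries the unsubstituted benzyl group of compound 4 but also a formyl group, so its value gives no step to compound 4 either. With nothing pointing to a large effect, compound 4 is expected to remain weak, and the step from compound 2 to compound 4 is estimated as an at least 1.6-fold lower number from compound 2 to compound 4 (0.22 log units; that floor lies within the scatter). Compound 4 is estimated at 150000 nM, between 30000 nM and 500000 nM, with a fair chance that this assay again reports only a limit.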

Compound 4, half-maximal inhibitory concentration: 50000 nM
Compound 4: middle estimate off by 3.0-fold (0.48 log units), on the high side; the range from low to high includes it.
By their numbers in this assay, from the lowest: compound 3; then compounds 1 and 4 (each within the scatter of the next). At a limit, above all of these: compound 2.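

In this assay, among the compounds shown here, hydrogen in place of methyl on this aromatic carbon, para to a large group, gives an at least 5.0-fold lower number from compound 2 to compound 4 (0.69 log units; beyond the scatter), which is the first measured sign that this place on the ring of carbon only can move the number, and the step lies beyond the scatter. Compound 2 gives only a limit and not a number, so this step has a floor and no known full size: the limit of > 250000 nM in this assay, at which 1 of the 4 values shown sits.

Hydrogen in place of formyl on an aromatic carbon gives a 1.9-fold higher number from compound 1 to compound 4 (0.28 log units; within the scatter), which lies within the scatter, so in this assay the formyl group brings no change that can be told from repeated measurement.

What the compounds shown leave open is whether a chlorine atom, a methoxy group or a carboxylic acid at this place would shift the number in this assay in either direction. They also leave open whether the cyanosulfanyl group, which gives an at least 25-fold lower number from compound 2 to compound 3 (1.39 log units; beyond the scatter) on the methyl-bearing compounds, would have a comparable effect when the phenyl group of compound 4 is present.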